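This account rests on a few compounds, and the source may have more. Where it says the series, first, only, none or still open, it means among the compounds named here.

Measured compounds in a functional assay on MCF7 cells (Homo sapiens) for inhibition; on this read-out lower numbers stand for stronger inhibition and higher numbers for weaker inhibition:
- compound 1 `CC1=NNC(=O)/C1=N/Nc1cccc(-c2nc3ccccc3s2)c1`; compound 1 gives > 25000 nM, a limit of the assay.
- compound 2 `O=C(Nc1cccc(-c2nc3ccccc3s2)c1)c1cccnc1`; compound 2 gives 15000 nM.
- compound 3 `Cc1ccc2nc(N/N=C/c3cccnc3Nc3ccccc3)sc2c1`; compound 3 gives 1690 nM.

Compound 1 sits at the limit of this assay, and compound 2 lies below that limit. Within the data shown here, the only step between measured compounds is an at least 1.6-fold lower number from compound 1 to compound 2 (0.22 log units; that floor lies within the scatter), and it exchanges the whole five-membered ring on the aromatic nitrogen for a pyridine-carbonyl group, so it says little about smaller changes kept within the ring.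

Compound 4 `CC(=O)N1N=C(C)/C(=N\Nc2cccc(-c3nc4ccccc4s3)c2)C1=O` is the open compound. It differs from compound 1 by acetyl in place of hydrogen on an amide-type nitrogen in a ring, the acetyl placed on an amide-type nitrogen in a ring. Among the measured compounds shown here, no measured step touches that nitrogen, so there is no ground for expecting a step beyond the scatter in either direction; the only comparison available, from compound 1 at the limit to compound 2, concerns a different part of the molecule. The expected step is a step that the limit leaves unreadable from compound 1 to compound 4. Compound 4 is therefore expected at about 30000 nM, in the range 8000 nM to 100000 nM, most likely again reported only as a limit.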

Compound 4, half-maximal inhibitory concentration: 12300 nM
The estimate for compound 4 lay 2.4-fold (0.39 log units) above the measured number; measured number inside the range.
By their numbers in this assay, from the lowest: compound 3; then compounds 4 and 2 (each within the scatter of the next). At a limit, above all of these: compound 1.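

In this assay, among these compounds, compound 4 gives a readable value of 12300 nM, so this amide-type nitrogen in the ring carries an acetyl with activity still measurable, which no earlier compound showed for this position. The change of hydrogen to acetyl gives an at least 2.0-fold lower number from compound 1 to compound 4 (0.30 log units; that floor lies within the scatter), and that floor alone does not establish a real gain. The true size of the step cannot be read because compound 1 stands at a limit: the limit of > 25000 nM in this assay, at which 1 of the 4 values shown sits.

Open, on these data alone, is whether any group on this nitrogen produces a step clearly beyond the scatter, and whether the carbonyl of the acetyl matters at all. A methyl, a longer acyl chain such as propionyl, or a carboxylic acid on the same nitrogen of the core of compound 1 would help to answer this.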